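Methoxy on the Phenylpiperazine Arm: Cytotoxicity Outlook

The compounds below may be only part of what the source reports. "The series", "measured", "known", "first", "only" and "open" are said of these compounds alone.

Compound 1 `O=C(CN1CCN(c2ccccc2)CC1)N1CCN(c2nnc(-c3ccccc3)c(-c3ccccc3)n2)CC1` is the parent of this small set. In an ADME assay on NIH3T3 cells (Mus musculus) for cytotoxicity, read by MTT assay, with a stated time of 24 h (on this read-out lower numbers stand for stronger inhibition and higher numbers for weaker inhibition), compound 1 gives only a limit of > 963000 nM (the limit of > 963000 nM in this assay, at which 1 of the 2 values shown sits), so its standing is a limit rather than a number. Compound 2 `O=C(CN1CCN(c2ccccc2Cl)CC1)N1CCN(c2nnc(-c3ccccc3)c(-c3ccccc3)n2)CC1` carries chloro in place of hydrogen on an aromatic carbon, and in this assay compound 2 gives 350000 nM; the step is an at least 2.7-fold lower number from compound 1 to compound 2 (0.43 log units; beyond the scatter). Compound 3 `COc1ccc(N2CCN(CC(=O)N3CCN(c4nnc(-c5ccccc5)c(-c5ccccc5)n4)CC3)CC2)cc1` differs from compound 1 by methoxy in place of hydrogen on an aromatic carbon. Going by the values given here, only that one step bears on the change, and it was at least modest toward lower numbers. Compound 3 is therefore expected to show a step of an at least 1.6-fold lower number from compound 1 to compound 3 (0.20 log units; that floor lies within the scatter), with an estimated value of 600000 nM, ranging from 250000 nM to 1500000 nM.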

Compound 3, half-maximal inhibitory concentration: > 910000 nM
Compound 3: a limit, no number; the forecaster's own chance of this, stated with the estimate: 40%; middle value at least 1.5-fold (0.18 log units) away from the limit.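

In this assay compound 3 gives only a limit, > 910000 nM, so 4-methoxyphenyl, like the plain phenyl of compound 1, yields no exact number. The step between those two limits cannot be read. The comparison with the chloro compound can be read, and it shows an at least 2.6-fold higher number from compound 2 to compound 3 (0.41 log units; beyond the scatter), so among these three compounds only the 2-chlorophenyl arm reaches a measured number.

Going by these compounds, whether methoxy moves the number at all stays open. So does how an amine or a carboxylic acid in its place would read in this assay.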